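Swapping ethylcarbamoyl for 3,3-dimethylbutyl on the ring nitrogen

The source may hold more compounds than are shown below. What is called first, only, known or untested is meant among the compounds shown, and "the series" means these compounds.

Within the data shown here, compound 3 `CCNC(=O)N1CCC[C@H]1C(=O)N1CCC(NS(=O)(=O)c2cc(S(=O)(=O)c3ccccc3)ccc2C(F)(F)F)CC1` gives 30 nM in an assay on isolated protein for binding affinity to secreted frizzled-related protein 1 (Homo sapiens), read by fluorescence (on this read-out lower numbers stand for stronger inhibition and higher numbers for weaker inhibition), the second highest of the three numbers measured so far: compound 2 `CC(C)(C)CC(=O)N1CCC[C@H]1C(=O)N1CCC(NS(=O)(=O)c2cc(S(=O)(=O)c3ccccc3)ccc2C(F)(F)F)CC1` gives 20 nM, a gap within the scatter, while compound 1 `CC(=O)N1CCC[C@H]1C(=O)N1CCC(NS(=O)(=O)c2cc(S(=O)(=O)c3ccccc3)ccc2C(F)(F)F)CC1` gives 160 nM, clearly further away. Compound 4 `CC(C)(C)CCN1CCC[C@H]1C(=O)N1CCC(NS(=O)(=O)c2cc(S(=O)(=O)c3ccccc3)ccc2C(F)(F)F)CC1` differs from compound 3 by 3,3-dimethylbutyl in place of ethylcarbamoyl on an amine nitrogen in a ring. The measured steps each change only what sits on that carbonyl and keep the carbonyl itself: an 8.0-fold lower number from compound 1 to compound 2 (0.90 log units; beyond the scatter), a 5.3-fold lower number from compound 1 to compound 3 (0.73 log units; beyond the scatter) and a 1.5-fold higher number from compound 2 to compound 3 (0.18 log units; within the scatter). Among the measured compounds shown here, none removes the carbonyl, so they bear only loosely on this change, and the large chain of compound 2 is the nearest precedent. Compound 4 is expected to come out somewhat weaker, a 2.7-fold higher number from compound 3 to compound 4 (0.43 log units; beyond the scatter), with wide uncertainty. Compound 4 is therefore estimated at 80 nM, between 20 nM and 400 nM.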

Compound 4, half-maximal inhibitory concentration: 30 nM
For compound 4 the middle estimate is 2.7-fold (0.43 log units) above the measured one; the measured number falls inside the stated range.
By their numbers in this assay, from the lowest: compounds 2, 3 and 4 (each within the scatter of the next); then compound 1.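

Without the carbonyl, and with no hydrogen-bond donor or acceptor in the group on the ring nitrogen, the number holds in this assay (no change at the digits printed from compound 3 to compound 4 (within the scatter)), and removing the carbonyl from the neopentylcarbonyl group gives a step within the scatter (a 1.5-fold higher number from compound 2 to compound 4 (0.18 log units; within the scatter)). So neither that carbonyl nor the amide hydrogen is needed to stay in this range. The acetyl group of compound 1 still stands apart (a 5.3-fold lower number from compound 1 to compound 4 (0.73 log units; beyond the scatter)), and no evidence is available to explain these results. From the compounds shown here alone, whether a short chain such as ethyl on this nitrogen would match 3,3-dimethylbutyl remains open, as does the effect of a carboxylic acid at the chain end.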